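The source may report more compounds than this note shows. Statements on the series, on what has been measured and on what is new or still open speak of the compounds shown alone.

Compound 1 `CCCN(CCC)c1cc(C(F)(F)F)ccc1CNC(=O)C(C)c1ccc(NS(C)(=O)=O)c(F)c1` stands lowest of the three numbers in hand. In an assay on CHO cells for antagonist activity at transient receptor potential cation channel subfamily V member 1 (Homo sapiens), read by FLIPR (on this read-out higher numbers stand for weaker inhibition and lower numbers for stronger inhibition), compound 1 gives 0.3 nM. Compound 2 `CC(C(=O)NCc1ccc(C(F)(F)F)cc1N1CCCCCC1)c1ccc(NS(C)(=O)=O)c(F)c1` gives 1.6 nM in this assay, and compound 3 `CC(C(=O)NCc1ccc(C(F)(F)F)cc1SCc1ccccc1)c1ccc(NS(C)(=O)=O)c(F)c1` gives 0.5 nM in this assay. Of the two steps away from compound 1, the change to an azepan-1-yl group in place of dipropylamino gave a 5.3-fold higher number from compound 1 to compound 2 (0.73 log units; beyond the scatter), whereas the change to benzylsulfanyl in place of dipropylamino gave a 1.7-fold higher number from compound 1 to compound 3 (0.22 log units; within the scatter). Between the two other compounds the step was a 3.2-fold lower number from compound 2 to compound 3 (0.51 log units; beyond the scatter).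

Compound 4 `COc1ccc(CSc2cc(C(F)(F)F)ccc2CNC(=O)C(C)c2ccc(NS(C)(=O)=O)c(F)c2)cc1` differs from compound 1 by (4-methoxybenzyl)sulfanyl in place of dipropylamino on an aromatic carbon. The step from compound 1 to compound 3 bears on this change most directly, since it places a related sulfanyl group at the same aromatic carbon, and that step stayed within the scatter. Compound 4 is therefore expected to stay close to compound 1, with at most a slight rise in this assay, that is a 2.0-fold higher number from compound 1 to compound 4 (0.30 log units; within the scatter). Compound 4 is estimated at 0.6 nM, between 0.2 nM and 2 nM.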

Compound 4, inhibition constant: 2.3 nM
Compound 4: middle estimate off by 3.8-fold (0.58 log units), on the low side; the measured number lies above the stated range.
By their numbers in this assay, from the lowest: compounds 1 and 3 (each within the scatter of the next); then compounds 2 and 4 (each within the scatter of the next).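

Within the sulfanyl pair, methoxy in place of hydrogen on an aromatic carbon gave a 4.6-fold higher number from compound 3 to compound 4 (0.66 log units; beyond the scatter) in this assay, so the close match between benzylsulfanyl and dipropylamino did not extend to (4-methoxybenzyl)sulfanyl. Set against dipropylamino, the new group gave a 7.7-fold higher number from compound 1 to compound 4 (0.88 log units; beyond the scatter), whereas set against azepan-1-yl it gave a 1.4-fold higher number from compound 2 to compound 4 (0.16 log units; within the scatter), a step that stays within the scatter. Nothing available accounts for the effect of the methoxy group.

As far as these compounds go, it remains open whether a fluoro, chloro or hydroxy group on the same aromatic ring would act as methoxy does, or whether the effect is particular to methoxy. Also open, from the compounds shown here alone, is whether benzyloxy or benzylamino could replace benzylsulfanyl at this position without a similar change.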